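Aryl ether replacements for the dichlorobenzoyloxy group

A few compounds are considered here, and "the series" means these few. Any claim that something is new, unique, unknown or untested is made for them only; others in the source may bear on it.

Compound 1 `CC(C)[C@H](NC(=O)COc1cccc2ccccc12)C(=O)N[C@@H](CC(=O)O)C(=O)COC(=O)c1c(Cl)cccc1Cl` carries a (2,6-dichlorophenyl)carbonyl on an oxygen on a saturated carbon. In a functional assay on Jurkat cells (Homo sapiens) (on this read-out higher numbers stand for weaker inhibition and lower numbers for stronger inhibition), compound 1 gives 10600 nM, the lowest of the two numbers shown, with compound 3 `CC(C)[C@H](NC(=O)COc1cccc2ccccc12)C(=O)N[C@@H](CC(=O)O)C(=O)COc1ccc(F)cc1F` nearest at 33200 nM; compound 2 `CC(C)[C@H](NC(=O)COc1cccc2ccccc12)C(=O)N[C@@H](CC(=O)O)C(=O)COc1cccc2ccccc12` gives only a limit of the assay, > 100000 nM, the case noted as the limit of > 100000 nM in this assay, at which 1 of the 3 values shown sits. The two measured steps from compound 1 both go in one direction: an at least 9.4-fold higher number from compound 1 to compound 2 (0.97 log units; beyond the scatter) and a 3.1-fold higher number from compound 1 to compound 3 (0.50 log units; beyond the scatter); between the aryl ethers, an at least 3.0-fold lower number from compound 2 to compound 3 (0.47 log units; beyond the scatter).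

Compound 4 `CC(C)[C@H](NC(=O)COc1cccc2ccccc12)C(=O)N[C@@H](CC(=O)O)C(=O)COc1cc(F)cc(F)c1F` makes the same kind of exchange: 2,3,5-trifluorophenyl in place of (2,6-dichlorophenyl)carbonyl on an oxygen on a saturated carbon. This resembles the step to compound 3 more closely than the step to compound 2, and a weakening of similar size is expected, a 2.8-fold higher number from compound 1 to compound 4 (0.45 log units; beyond the scatter). In this assay compound 4 is therefore estimated at 30000 nM, with a range from 12000 nM to 90000 nM.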

Compound 4, half-maximal inhibitory concentration: 30000 nM
Estimate against measurement, compound 4: no gap at the digits printed, and the stated range covers the measured number.
By their numbers in this assay, from the lowest: compound 1; then compounds 4 and 3 (each within the scatter of the next). At a limit, above all of these: compound 2.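

In this assay, exchanging 2,4-difluorophenyl for 2,3,5-trifluorophenyl on this oxygen does not separate the two ethers, with a 1.1-fold lower number from compound 3 to compound 4 (0.04 log units; within the scatter). The gap to the ester therefore does not belong to compound 3 alone, since the second fluorophenyl ether gives a 2.8-fold higher number from compound 1 to compound 4 (0.45 log units; beyond the scatter), and neither fluorophenyl ether matches the (2,6-dichlorophenyl)carbonyl group here. The naphthalen-1-yl ether also stays apart from this second fluorophenyl ether, with an at least 3.3-fold lower number from compound 2 to compound 4 (0.52 log units; beyond the scatter), a step with only one bound: the limit of > 100000 nM in this assay, at which 1 of the 4 values shown sits.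

Still open, from the compounds shown here alone, is whether the gap to compound 1 follows the carbonyl that leaves or the ring substituents. A 2,6-dichlorophenyl ether or an unsubstituted phenyl ether at this place would separate those two readings.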